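The source may hold more compounds than are shown below. What is called first, only, known or untested is meant among the compounds shown, and "the series" means these compounds.

Compound 1 `COc1cc(Nc2nc3ccccc3nc2S(=O)(=O)c2ccc(C)cc2)cc(OC)c1`: > 50000 nM
Compound 2 `COc1ccc(S(=O)(=O)c2nc3ccccc3nc2Nc2cc(OC)cc(OC)c2)cc1`: 13400 nM
Compound 3 `COc1ccc(S(=O)(=O)c2nc3ccccc3nc2Nc2ccc(C(F)(F)F)cc2)cc1`: 110 nM

Three compounds share one core and were tested in a functional assay on HCT-116 cells (Homo sapiens) for cytotoxicity, read by MTT assay, with a stated time of 72 h; a lower number here means a stronger inhibitor, a higher number a weaker inhibitor. For compound 1 the result is a limit of the assay rather than a number, > 50000 nM. Compound 2 gives 13400 nM, and compound 3 gives 110 nM. Among the numbers actually measured, compound 2 stands highest: the step of a 120-fold lower number from compound 2 to compound 3 (2.09 log units; beyond the scatter) separates it from compound 3, while compound 1 sits at the limit (the limit of > 50000 nM in this assay, at which 1 of the 3 values shown sits).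

Compound 4 `COc1cc(Nc2nc3ccccc3nc2S(=O)(=O)c2ccc(F)cc2)cc(OC)c1` differs from compound 2 in one place: fluoro in place of methoxy on an aromatic carbon. For the measured compounds named here, the one measured step that touches this position is an at least 3.7-fold lower number from compound 1 to compound 2 (0.57 log units; beyond the scatter), where a methyl gave way to a methoxy; the step of a 120-fold lower number from compound 2 to compound 3 (2.09 log units; beyond the scatter) concerns a different part of the molecule. A fluoro, like a methyl, lacks the acceptor that methoxy brings, so the change in this assay is expected to run the other way, back towards the weaker end, by a 2.1-fold higher number from compound 2 to compound 4 (0.32 log units; beyond the scatter). Compound 4 is therefore estimated to give 28000 nM in this assay, with a plausible range from 8000 nM to 90000 nM.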

Compound 4, half-maximal inhibitory concentration: 3930 nM
Beside the measured number, compound 4's estimate is 7.1-fold (0.85 log units) above it; measured number below the stated range.
By their numbers in this assay, from the lowest: compound 3; then compound 4; then compound 2. At a limit, above all of these: compound 1.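

Fluoro in place of methoxy on this aromatic carbon does not push the compound towards the weaker end in this assay: the change gives a 3.4-fold lower number from compound 2 to compound 4 (0.53 log units; beyond the scatter). The hydrogen-bond acceptor counted on methoxy is therefore not needed for a lower number in this pair, and methyl and fluoro, which both lack it, do not behave alike at this position, so the three groups now rank with fluoro giving the lowest number, then methoxy, then methyl. Fluoro in place of methyl gives an at least 12-fold lower number from compound 1 to compound 4 (1.10 log units; beyond the scatter), a size that is only a bound, as compound 1 stands at a limit of the assay: the limit of > 50000 nM in this assay, at which 1 of the 4 values shown sits.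

The compounds shown leave open how a chloro, a nitrile, an amine or a carboxylic acid would compare at this position, so three groups cannot yet show what sets the order among them. For the compounds shown here, they also leave open whether fluoro in place of methoxy would give a similar step when the nitrogen carries 4-(trifluoromethyl)phenyl, the group that gave the largest step so far, rather than 3,5-dimethoxyphenyl.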